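Changing the ring on the sulfur-linked benzyl arm

The source may hold more compounds than are shown below. What is called first, only, known or untested is meant among the compounds shown, and "the series" means these compounds.

Compound 1, `Cc1cc(-c2ccccc2)n(/C(N)=N/S(=O)(=O)c2cc(C)c(Cl)cc2SCc2cccc3ccccc23)n1`: 170000 nM in a functional assay on MCF7 cells (Homo sapiens) for cytotoxicity, read by MTT assay, with a stated time of 72 h; on this read-out lower numbers stand for stronger inhibition and higher numbers for weaker inhibition
Compound 2, `Cc1cc(-c2ccccc2)n(/C(N)=N/S(=O)(=O)c2cc(C)c(Cl)cc2SCc2ccc(C(F)(F)F)cc2)n1`: 16000 nM in this assay

Both compounds share one core and differ only in the ring carried on a saturated chain carbon bound to a sulfur. In this assay compound 1 gives 170000 nM, while compound 2 gives 16000 nM. Among the compounds with values here, the step of an 11-fold lower number from compound 1 to compound 2 (1.03 log units; beyond the scatter) is the only comparison measured so far, and it leaves compound 2 with the lowest number of the two. Compound 3, `Cc1cccc(CSc2cc(Cl)c(C)cc2S(=O)(=O)/N=C(\N)n2nc(C)cc2-c2ccccc2)c1`, has not yet been measured; it differs from compound 2 by 3-methylphenyl in place of 4-(trifluoromethyl)phenyl on a saturated chain carbon bound to a sulfur. Within the data shown here, the one measured step bears on this only indirectly: it shows that the ring on this chain carbon can move the number a great deal, but it does not compare either of the rings involved here with a single-ring group of this kind. For compound 3 the expected step is a 2.2-fold higher number from compound 2 to compound 3 (0.34 log units; beyond the scatter), toward a somewhat higher number, with wide uncertainty. Compound 3 is therefore estimated at 35000 nM, within 8000 nM to 150000 nM.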

Compound 3, half-maximal inhibitory concentration: 105000 nM
Beside the measured number, compound 3's estimate is 3.0-fold (0.48 log units) below it, and the stated range covers the measured number.
By their numbers in this assay, from the lowest: compound 2; then compounds 3 and 1 (each within the scatter of the next).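

A single ring on this chain carbon is not enough by itself to lower the number: in this assay, replacing naphthalen-1-yl with 3-methylphenyl gives a 1.6-fold lower number from compound 1 to compound 3 (0.21 log units; within the scatter), so these two compounds cannot be told apart. The low number of compound 2 therefore depends on which single ring is present, since replacing 4-(trifluoromethyl)phenyl with 3-methylphenyl gives a 6.6-fold higher number from compound 2 to compound 3 (0.82 log units; beyond the scatter) and loses most of the earlier gain. Nothing shown here explains why these rings give different numbers.

This change alters both the group on the ring and its place there, so the two cannot be separated; 4-methylphenyl or 3-(trifluoromethyl)phenyl on this carbon would pull them apart. Also open, going by these compounds, is what a ring carrying an amine or a carboxylic acid would give.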